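Butyl(propyl)amino on the triazolopyrimidine-free core: a return to zero donors

The compounds below may be only part of what the source reports. "The series", "measured", "known", "first", "only" and "open" are said of these compounds alone.

In an assay on cell membranes for displacement of a labelled ligand from corticotropin-releasing factor receptor 1 (Rattus norvegicus) (on this read-out lower numbers stand for stronger inhibition and higher numbers for weaker inhibition), compound 3 `CCCC(C)Nc1nc(C)nc2c(-c3ccc(OC)nc3C)c(C)nn12` gives 3.5 nM, the lowest of the three numbers; compound 1 `CCCCN(C)c1nc(C)nc2c(-c3ccc(OC)nc3C)c(C)nn12` gives 8.1 nM and compound 2 `CCC(CC)Nc1nc(C)nc2c(-c3cnc(N(C)C)cc3C)c(C)nn12` gives 24.8 nM. Compound 4 `CCCCN(CCC)c1nc(C)nc2c(-c3ccc(OC)nc3C)c(C)nn12` differs from compound 3 by butyl(propyl)amino in place of (1-methylbutyl)amino on an aromatic carbon. Among the measured compounds shown here, the one step that bears on it is the reverse of this direction: a 2.3-fold lower number from compound 1 to compound 3 (0.36 log units; beyond the scatter), where butyl(methyl)amino with no hydrogen-bond donor gave way to a group with one. Compound 4 again carries a group with no hydrogen-bond donor, so a modest rise in the number, roughly undoing that step, is expected. Compound 4 is therefore estimated at 8 nM, within 3 nM to 25 nM, meaning a 2.3-fold higher number from compound 3 to compound 4 (0.36 log units; beyond the scatter).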

Compound 4, half-maximal inhibitory concentration: 2.4 nM
For compound 4 the middle estimate is 3.3-fold (0.52 log units) above the measured one; measured number below the stated range.
By their numbers in this assay, from the lowest: compounds 4 and 3 (each within the scatter of the next); then compound 1; then compound 2.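

In this assay a hydrogen-bond donor at this position is not required for a low number: butyl(propyl)amino and (1-methylbutyl)amino cannot be told apart (a 1.5-fold lower number from compound 3 to compound 4 (0.16 log units; within the scatter)). Between the two groups with no donor, ethyl in place of hydrogen on the saturated chain carbon bound to the nitrogen does move the number (a 3.4-fold lower number from compound 1 to compound 4 (0.53 log units; beyond the scatter)), so the earlier step from compound 1 cannot be read as a matter of the donor alone. No evidence at hand accounts for these numbers.

On these data alone, how a ring amine such as morpholine or an ether-bearing group such as bis(2-methoxyethyl)amino would fare at this position remains open.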